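The source may report more compounds than this note shows. Statements on the series, on what has been measured and on what is new or still open speak of the compounds shown alone.

Compounds measured in a functional assay on T47D cells (Homo sapiens) for antiproliferative activity, with a stated time of 72 h; on this read-out higher numbers stand for weaker inhibition and lower numbers for stronger inhibition:
compound 1, `CCOC(=O)OCC#CCSc1c(SC)cnc2ccccc12`, 34.2 ug/mL;
compound 2, `CSc1cnc2ccccc2c1SCC#CCCl`, 3.9 ug/mL;
compound 3, `CSc1cnc2ccccc2c1[Se]CC#CCOC(=O)/C=C/c1ccccc1`, 4.3 ug/mL.

Compound 1 gives the highest of these three numbers; compound 3 and compound 2 both lie well below it, beyond the scatter. The unmeasured compound 4, `CSc1cnc2ccccc2c1SCC#CCOC(=O)/C=C/c1ccccc1`, differs from compound 1 by 2-phenylethenyl in place of ethoxy on a carbonyl carbon. For the measured compounds named here, the only measured step at this position is an 8.8-fold lower number from compound 1 to compound 2 (0.94 log units; beyond the scatter), a modest gain when the chain end is changed; compound 3, which gives 4.3 ug/mL, also shows that a far lower number than that of compound 1 is reachable. A step of similar size is therefore expected in this assay, a 7.6-fold lower number from compound 1 to compound 4 (0.88 log units; beyond the scatter). Compound 4 is estimated at 4.5 ug/mL, with a range from 1.5 ug/mL to 14 ug/mL.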

Compound 4, concentration for 50% inhibition: 71.9 ug/mL
Estimate against measurement, compound 4: 16-fold (1.20 log units) below; measured number above the stated range.
By their numbers in this assay, from the lowest: compounds 2 and 3 (each within the scatter of the next); then compound 1; then compound 4.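

In this assay, 2-phenylethenyl in place of ethoxy on the carbonyl carbon gives a 2.1-fold higher number from compound 1 to compound 4 (0.32 log units; beyond the scatter), against the direction of the chloro change in compound 2. A lower number is therefore not a general result of replacing the chain end. Compound 4 carries sulfur where selenium stands in compound 3, and compound 3 gives 4.3 ug/mL, so 2-phenylethenyl on the carbonyl carbon does not bring a high number in every compound.

Going by these compounds, whether an amine, a carboxylic acid or a longer chain at this chain end would behave like chloro or like 2-phenylethenyl stays open. No measurement shown here explains the higher number of compound 4.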